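The compounds below may be only part of what the source reports. "The series", "measured", "known", "first", "only" and "open" are said of these compounds alone.

Compound 2 `[O-][n+]1nc(NCOC2CCCCC2)[n+]([O-])c2ccccc21` is one of three compounds tested in a functional assay on A549 cells (Homo sapiens) for cytotoxicity, read by MTT assay, with a stated time of 72 h; on this read-out higher numbers stand for weaker inhibition and lower numbers for stronger inhibition. In this assay compound 2 gives 5180 nM, the second highest of the three numbers; compound 3 `CCCCCOCNc1n[n+]([O-])c2ccccc2[n+]1[O-]` gives 6460 nM and compound 1 `CCCOCNc1n[n+]([O-])c2cc(OC)ccc2[n+]1[O-]` gives 2810 nM, both within the scatter of the number for compound 2. Compound 4 `CCOCNc1n[n+]([O-])c2ccccc2[n+]1[O-]` has not yet been measured; it differs from compound 2 by ethyl in place of cyclohexyl on an oxygen on a saturated carbon. Within the data shown here, the only measured step at this place is a 1.2-fold higher number from compound 2 to compound 3 (0.10 log units; within the scatter), pentyl in place of cyclohexyl on an oxygen on a saturated carbon, and it stays within the scatter. A shorter chain at the same place is therefore expected to shift the number little, so the expected step is a 1.0-fold lower number from compound 2 to compound 4 (0.02 log units; within the scatter). Compound 4 is estimated at 5000 nM, with a range from 2500 nM to 10000 nM.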

Compound 4, half-maximal inhibitory concentration: 10500 nM
Beside the measured number, compound 4's estimate is 2.1-fold (0.32 log units) below it, outside the stated range (above it).
By their numbers in this assay, from the lowest: compounds 1, 2, 3 and 4 (each within the scatter of the next, the first and the last beyond it).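

Among these compounds, putting ethyl in place of cyclohexyl on the oxygen gives a 2.0-fold higher number from compound 2 to compound 4 (0.31 log units; beyond the scatter) in this assay, the first step at this place to pass the scatter, though only modestly. Going from the pentyl chain to the ethyl chain gives a 1.6-fold higher number from compound 3 to compound 4 (0.21 log units; within the scatter), so these two straight chains cannot be told apart, and only the cyclohexyl-to-ethyl change shows that this place responds at all. Nothing available explains this shift. On these data alone, whether a longer chain such as octyl, or a chain ending in an amine or a carboxylic acid, would move the number further remains open.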